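Propargyloxy to phenoxy: notes on the series

The source may hold more compounds than are shown below. What is called first, only, known or untested is meant among the compounds shown, and "the series" means these compounds.

Values in a functional assay on HCT-116 cells (Homo sapiens) for inhibition, read by sulforhodamine B assay, with a stated time of 48 h, tested at 50 uM (a lower number here means less inhibition of growth, a higher number more inhibition of growth at the concentration tested), for the measured compounds
compound 1 `CCOc1ccc([C@@H]2CC(=O)c3cc(CC=C(C)C)c(OC)cc3O2)cc1` gives 65%
compound 2 `C#CCOc1ccc([C@@H]2CC(=O)c3cc(CC=C(C)C)c(OC)cc3O2)cc1` gives 75%

Compound 2 at 75% stands within the scatter of compound 1. The next change is phenyl in place of propargyl on an oxygen on an aromatic ring, which leads to compound 3 `COc1cc2c(cc1CC=C(C)C)C(=O)C[C@@H](c1ccc(Oc3ccccc3)cc1)O2` with phenyl in place of propargyl on an oxygen on an aromatic ring as the counted difference. Among the compounds with values here, one measured step bears on it, at the same oxygen, namely a number 10 percentage points higher from compound 1 to compound 2 (within the scatter) and so it gives only a small step to go on. Within the data shown here, no measured compound carries a ring on that oxygen, which leaves the expectation uncertain. In this assay no shift beyond the scatter is expected, and the estimate gives a number 7 percentage points lower from compound 2 to compound 3 (within the scatter) as the expected step. The estimate for compound 3 is 68% within an expected range of 45% to 85% for now.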

Compound 3, percent growth inhibition at one concentration: 76%
Compound 3: middle estimate off by 8 percentage points, on the low side; the range from low to high includes it.
By their numbers in this assay, from the lowest: compounds 1, 2 and 3 (each within the scatter of the next, the first and the last beyond it).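

In this assay a ring on the oxygen on an aromatic ring is as compatible with growth inhibition as the propargyl chain, with a number 1 percentage points higher from compound 2 to compound 3 (within the scatter) and no distinction between the two groups at this place. Against ethyl, the same place now gives the first step in the series to clear the scatter, a number 11 percentage points higher from compound 1 to compound 3 (beyond the scatter) and this is still a single, modest difference. Nothing measured here accounts for either step.

The compounds leave open whether that difference belongs to phenyl itself or would also appear with benzyl, a longer chain such as butyl, or a chain ending in an amine on the same oxygen. On these data alone, all three compounds share the rest of the core and are read at one concentration, so how the phenyl step would hold on another core or across a concentration range remains unknown.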